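The source may report more compounds than this note shows. Statements on the series, on what has been measured and on what is new or still open speak of the compounds shown alone.

Measured compounds:
compound 1, `O=S(=O)(NCCNCc1ccc(-c2ccccc2)cc1)c1cc(C(F)(F)F)cc(C(F)(F)F)c1`: 2800 nM
compound 2, `O=S(=O)(NCCCNCc1ccc(C(F)(F)F)cc1)c1cc(C(F)(F)F)cc(C(F)(F)F)c1`: 2700 nM
compound 3, `O=S(=O)(NCCNCc1cccc2ccccc12)c1cc(C(F)(F)F)cc(C(F)(F)F)c1`: 18000 nM

Of the compounds shown here, three sharing the same sulfonamide-bearing core have been tested in a functional assay on HPAC cells (Homo sapiens) for inhibition, read by MTT assay, with a stated time of 72 h; on this read-out lower numbers stand for stronger inhibition of growth and higher numbers for weaker inhibition of growth. In this assay compound 2 gives 2700 nM, the lowest of the three numbers. Compound 1 stands closest to it with 2800 nM, a difference that lies within the usual scatter, so the two cannot be told apart. Compound 3, with 18000 nM, sits clearly higher, beyond the scatter.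

The next compound to be measured is compound 4, `O=S(=O)(NCCCNCc1ccc(Br)cc1)c1cc(C(F)(F)F)cc(C(F)(F)F)c1`. Compared with compound 2 it carries one change: bromo in place of trifluoromethyl on an aromatic carbon. Nothing measured here speaks to such a change, so the expectation rests on compound 2 alone. The step from compound 2 to compound 4 is expected to be small, a 1.3-fold higher number from compound 2 to compound 4 (0.11 log units; within the scatter), most likely not beyond the scatter. Compound 4 is therefore estimated at 3500 nM in this assay, with a range from 1500 nM to 8500 nM.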

Compound 4, concentration for 50% growth inhibition: 2900 nM
Estimate against measurement, compound 4: 1.2-fold (0.08 log units) above, and the stated range covers the measured number.
By their numbers in this assay, from the lowest: compounds 2, 1 and 4 (each within the scatter of the next); then compound 3.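

Going from 4-(trifluoromethyl)benzyl to 4-bromobenzyl gives the first comparison in this series of compounds that differ in one place, and in this assay it reads as a 1.1-fold higher number from compound 2 to compound 4 (0.03 log units; within the scatter), so the two groups cannot be told apart here. On this aromatic carbon, para to a large group, a single bromine can therefore stand in for the four heavy atoms of trifluoromethyl with no step beyond the scatter, at least in this one pair. No supporting measurement is available to explain this result.

Going by these compounds, it remains open whether the same holds for other groups at this place, such as a nitrile, a methoxy group, an amine or a carboxylic acid. Also open, on these data alone, is how a longer chain would read with the 4-bromobenzyl group kept in place.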